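Sugar swap on a triazole-linked cytotoxic core

The compounds below may be only part of what the source reports. "The series", "measured", "known", "first", "only" and "open" are said of these compounds alone.

Measured compounds:
- compound 1, `O=C1c2c[n+]([O-])c3ccccc3c2C(=O)c2c1c1ccccc1n2Cc1cn([C@H]2C[C@H](O)[C@@H](CO)O2)nn1`: 3600 nM
- compound 2, `CN1CCN(CCCn2c3c(c4ccccc42)C(=O)c2c[n+]([O-])c4ccccc4c2C3=O)CC1`: 170 nM

In a toxicity assay on HEK-293T cells (Homo sapiens) for cytotoxicity, read by MTT assay, with a stated time of 72 h (on this read-out lower numbers stand for stronger inhibition and higher numbers for weaker inhibition), compound 1 gives 3600 nM, the higher of the two numbers shown, while compound 2 gives 170 nM. Compound 3, `O=C1c2c[n+]([O-])c3ccccc3c2C(=O)c2c1c1ccccc1n2Cc1cn([C@@H]2O[C@H](CO)[C@@H](O)[C@H](O)[C@H]2O)nn1`, has not yet been measured. It differs from compound 1 in one place: 3,4,5-trihydroxy-6-(hydroxymethyl)oxan-2-yl in place of 4-hydroxy-5-(hydroxymethyl)oxolan-2-yl on an aromatic nitrogen. For the measured compounds named here, no measured pair shows what such a sugar change does on the shared core, so nothing here points in a clear direction. For compound 3 the expectation is a step of a 1.3-fold higher number from compound 1 to compound 3 (0.10 log units; within the scatter), barely beyond the scatter, with a value estimated at 4500 nM, in the range 1500 nM to 13000 nM.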

Compound 3, half-maximal inhibitory concentration: 940 nM
Beside the measured number, compound 3's estimate is 4.8-fold (0.68 log units) above it, and the stated range ends above it.
By their numbers in this assay, from the lowest: compound 2; then compound 3; then compound 1.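

In this assay, the sugar on the aromatic nitrogen of the five-membered ring does affect the result: 3,4,5-trihydroxy-6-(hydroxymethyl)oxan-2-yl in place of 4-hydroxy-5-(hydroxymethyl)oxolan-2-yl gives a 3.8-fold lower number from compound 1 to compound 3 (0.58 log units; beyond the scatter). This modest step lies beyond the scatter, so this position responds to a change of sugar on the shared core. Nothing available explains the direction of this step.

Still open, as far as these compounds go, is whether a carboxylic acid or a simple amine in place of the sugar would shift the number further. It is also unclear whether the arrangement of the sugar's defined stereocentres matters.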